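Cytotoxicity notes: cyclohexyl to 4-chlorophenyl on the shared core

This account rests on a few compounds, and the source may have more. Where it says the series, first, only, none or still open, it means among the compounds named here.

Of the compounds shown here, two have numbers so far. In a functional assay on HEL cells (Homo sapiens) for cytotoxicity (on this read-out lower numbers stand for higher toxicity in this test and higher numbers for lower toxicity in this test), compound 1 (`O[C@@H]1[C@@H](O)[C@H](c2ccccc2)O[C@@H]2CO[C@@H](c3ccc(C(F)(F)F)cc3)O[C@@H]12`) gives 35 ug/mL, and compound 2 (`CO[C@@H]1[C@@H](OC)[C@H](c2ccccc2)O[C@@H]2CO[C@@H](C3CCCCC3)O[C@@H]12`) gives 28 ug/mL. These two values lie within the scatter of each other, so compound 2 stands level with compound 1 and the pair cannot be ranked.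

Compound 3 (`CO[C@@H]1[C@@H](OC)[C@H](c2ccccc2)O[C@@H]2CO[C@@H](c3ccc(Cl)cc3)O[C@@H]12`) has not yet been measured. It carries 4-chlorophenyl in place of cyclohexyl on a saturated ring carbon, between two ring oxygen atoms: 4-chlorophenyl in place of cyclohexyl on a saturated ring carbon.

Within the data shown here, no measured pair differs in one place, so the series offers no direct guide to the size of this change. Among the measured compounds shown here, the only evidence is the narrow spread of the two known values, with compound 1 at 35 ug/mL and compound 2 at 28 ug/mL. On that basis, no shift beyond the scatter is expected in this assay, and no direction is favoured. The expected 1.1-fold higher number from compound 2 to compound 3 (0.03 log units; within the scatter) is correspondingly small. For compound 3, the estimated value is 30 ug/mL, with an expected range of 13 ug/mL to 70 ug/mL.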

Compound 3, half-maximal cytotoxic concentration: > 50 ug/mL
Compound 3: a limit, no number; the forecaster's own chance of this, stated with the estimate: 15%; middle value at least 1.6-fold (0.22 log units) from the limit.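

Compound 3 reads > 50 ug/mL in this assay, and this is a limit of the assay, not a number. Placing 4-chlorophenyl in place of cyclohexyl on a saturated ring carbon, between two ring oxygen atoms, gives the first single-place step in the series, an at least 1.7-fold higher number from compound 2 to compound 3 (0.25 log units; that floor lies within the scatter), so this position on the shared core takes an aromatic ring bearing chlorine with no fall in the number for cytotoxicity. Only the floor of this step can be read, and since that floor lies within the scatter, the step cannot yet be called a real separation of compound 3 from compound 2: the limit of > 50 ug/mL in this assay, at which 1 of the 3 values shown sits.

The compounds shown do not separate the contribution of the aromatic ring from that of the chlorine, and a plain phenyl at this ring carbon would be the direct test of that question. From the compounds shown here alone, it also remains open how this position responds to groups of a different kind, such as an amine, a carboxylic acid or a longer alkyl chain.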